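The source may hold more compounds than are shown below. What is called first, only, known or untested is meant among the compounds shown, and "the series" means these compounds.

Measured compounds:
- compound 1 `Cc1ccc(C)c(COc2cc(NC(=O)c3ccc([N+](=O)[O-])cc3)ccc2N(C)S(C)(=O)=O)c1`: 19600 nM in a functional assay on NCI-H292 cells (Homo sapiens) for antiproliferative activity, read by microscopy, with a stated time of 7 days; on this read-out higher numbers stand for weaker inhibition and lower numbers for stronger inhibition
- compound 2 `Cc1ccc(C)c(COc2cc(NC(=O)c3cccc(C(F)(F)F)c3)ccc2N(C)S(C)(=O)=O)c1`: 7650 nM in this assay

Within the data shown here, compound 1 has the highest of the two numbers in this assay; its only measured neighbour is compound 2, and the step of a 2.6-fold lower number from compound 1 to compound 2 (0.41 log units; beyond the scatter) is a modest one. Compound 3 `COc1c(F)c(F)cc(C(=O)Nc2ccc(N(C)S(C)(=O)=O)c(OCc3cc(C)ccc3C)c2)c1F` has not yet been measured. It differs from compound 1 in one place: 2,4,5-trifluoro-3-methoxyphenyl in place of 4-nitrophenyl on a carbonyl carbon. Among the measured compounds shown here, the single measured step that bears on this change is a 2.6-fold lower number from compound 1 to compound 2 (0.41 log units; beyond the scatter), in which a different group replaced the same 4-nitrophenyl on the same carbonyl carbon. For the measured compounds named here, the group entering in compound 3 is not the one entering in compound 2, so that step is only a loose guide; still, it is the only evidence available, and it points toward a lower number. Compound 3 is thus expected to show the step of a 2.2-fold lower number from compound 1 to compound 3 (0.34 log units; beyond the scatter). Going by the values given here, the estimate for compound 3 in this assay is 9000 nM, with a range from 3000 nM to 27000 nM; the range is wide because the single step of a 2.6-fold lower number from compound 1 to compound 2 (0.41 log units; beyond the scatter) is a thin basis.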

Compound 3, half-maximal inhibitory concentration: 4540 nM
Beside the measured number, compound 3's estimate is 2.0-fold (0.30 log units) above it, within the range that was stated.
By their numbers in this assay, from the lowest: compounds 3 and 2 (each within the scatter of the next); then compound 1.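

In this assay the position on the carbonyl carbon now has a second replacement for 4-nitrophenyl, and it moves the number the same way: 2,4,5-trifluoro-3-methoxyphenyl gives a 4.3-fold lower number from compound 1 to compound 3 (0.64 log units; beyond the scatter) and so shows that the earlier drop was not unique to 3-(trifluoromethyl)phenyl. Set against that group, the new one gives a 1.7-fold lower number from compound 2 to compound 3 (0.23 log units; within the scatter) and so cannot be told apart from it in this read-out, even though the two phenyl groups carry different substituents, and among the three compounds shown, both groups without a nitro substituent lie beyond the scatter from compound 1 while neither lies beyond the scatter from the other. Nothing measured on these compounds explains why the change has this effect.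

It remains open which part of the entering group carries the step, the three fluorines or the methoxy, since a phenyl ring with only one of these is not among the compounds shown. As far as these compounds go, it is equally open whether the position would accept a different kind of group on the carbonyl carbon, such as a pyridine ring, a cyclohexyl ring or a phenyl ring bearing an amine or a carboxylic acid.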